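Thiophen-2-yl for 4-methylphenyl on a sulfonyl sulfur

The source may hold more compounds than are shown below. What is called first, only, known or untested is meant among the compounds shown, and "the series" means these compounds.

Compound 1 `Cc1ccc(S(=O)(=O)N2C(=O)COC23C=CC(=O)C=C3)cc1`: 70 nM
Compound 2 `O=C1C=CC2(C=C1)OCC(=O)N2S(=O)(=O)c1ccc(C(F)(F)F)cc1`: 2100 nM

In a functional assay on MDA-MB-231 cells (Homo sapiens) for inhibition, read by sulforhodamine B assay, with a stated time of 74 h (a lower number here means a stronger inhibitor, a higher number a weaker inhibitor), compound 1 holds the lower of the two numbers, well beyond the scatter. Compound 3 `O=C1C=CC2(C=C1)OCC(=O)N2S(=O)(=O)c1cccs1` has thiophen-2-yl in place of 4-methylphenyl on a sulfonyl sulfur. Among the compounds with values here, only one measured step bears on this change, and only indirectly: a 30-fold higher number from compound 1 to compound 2 (1.48 log units; beyond the scatter), a large step from trifluoromethyl in place of methyl on an aromatic carbon. Within the data shown here, with that step as the sole guide to this part of the molecule, a moderate rise is expected in this assay. The expected step is a 3.6-fold higher number from compound 1 to compound 3 (0.55 log units; beyond the scatter). For compound 3 the estimate is 250 nM, with an expected range of 50 nM to 1300 nM.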

Compound 3, half-maximal inhibitory concentration: 20 nM
Estimate against measurement, compound 3: 13-fold (1.10 log units) above, and the stated range ends above it.
By their numbers in this assay, from the lowest: compound 3; then compound 1; then compound 2.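

Replacing the whole aromatic group on the sulfonyl sulfur need not cost activity: in this assay thiophen-2-yl gives a 3.5-fold lower number from compound 1 to compound 3 (0.54 log units; beyond the scatter) and so holds the lowest number of the three compounds. Within the data shown here, the only earlier step here, a 30-fold higher number from compound 1 to compound 2 (1.48 log units; beyond the scatter) for this assay, went the other way, and it changed a group on the benzene ring, not the ring itself. Nothing available here explains the gain.

From the compounds shown here alone, whether the sulfonyl sulfur also tolerates furan-2-yl, pyridin-3-yl or a longer alkyl chain remains open, as does the effect of an amine on the thiophene ring.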